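A Dichlorophenyl Analogue of a Piperazine Aminothiophene

The source may hold more compounds than are shown below. What is called first, only, known or untested is meant among the compounds shown, and "the series" means these compounds.

Compound 2 `Nc1scc(CN2CCN(c3cc(F)cc(F)c3)CC2)c1C(=O)c1ccc(Cl)cc1` is the stronger of the two measured compounds in a functional assay on CHO cells with adenosine receptor A1 (Homo sapiens) as the target, read by cAMP accumulation and immunoassay, with a stated time of 6 min, tested at 10 uM (a higher number here means a weaker effect of the compound at the concentration tested, a lower number a stronger effect), where compound 2 gives -79%. Within the data shown here, its nearest neighbour is compound 1 `Nc1scc(CN2CCN(c3ccccc3F)CC2)c1C(=O)c1ccc(Cl)cc1`, and in this assay compound 1 gives -15%; the single measured step, a number 64 percentage points lower from compound 1 to compound 2 (beyond the scatter), covers the exchange of 2-fluorophenyl for 3,5-difluorophenyl on the amine nitrogen in the ring.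

Compound 3 `Nc1scc(CN2CCN(c3ccc(Cl)c(Cl)c3)CC2)c1C(=O)c1ccc(Cl)cc1` differs from compound 2 by 3,4-dichlorophenyl in place of 3,5-difluorophenyl on an amine nitrogen in a ring. Among the measured compounds shown here, no measured step bears directly on this change: the one known step swaps fluorine positions, whereas here two chlorines enter at new positions. For the measured compounds named here, the only guidance is that the substitution pattern on the phenyl attached to the ring nitrogen moved the read-out by a large amount in the step from compound 1 to compound 2, so a sizeable shift is possible in either direction. Compound 3 is expected to stay clearly active, with an estimated step of a number 14 percentage points higher from compound 2 to compound 3 (beyond the scatter). The estimate for compound 3 is -65%, ranging from -95% to -30%.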

Compound 3, a percentage reported as activity, at one concentration (the size of the read-out at that concentration, not a potency): -62%
For compound 3 the middle estimate is 3 percentage points below the measured one, and the stated range covers the measured number.
By their numbers in this assay, from the lowest: compound 2; then compound 3; then compound 1.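

In this assay, this place on the ring nitrogen accepts a change of both halogen and substitution pattern without losing the effect: the step of a number 17 percentage points higher from compound 2 to compound 3 (beyond the scatter) is modest, so 3,4-dichlorophenyl falls short of 3,5-difluorophenyl but stays close to it. The step of a number 47 percentage points lower from compound 1 to compound 3 (beyond the scatter) shows that it keeps most of the large gain over 2-fluorophenyl, so that gain does not belong to 3,5-difluorophenyl alone, and both phenyl groups with two halogens stand well below the one with a single fluorine. Nothing measured here accounts for these differences.

From the compounds shown here alone, the step from 3,5-difluorophenyl to 3,4-dichlorophenyl changes halogen and pattern together, so the share of each stays open, and 3,5-dichlorophenyl or 3,4-difluorophenyl would part them. Also open, going by these compounds, is how this read-out responds to an unsubstituted phenyl, or to a phenyl bearing a methoxy group or an amine.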